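A few compounds are considered here, and "the series" means these few. Any claim that something is new, unique, unknown or untested is made for them only; others in the source may bear on it.

Working notes on the series.

Compound 2 `COc1ccc(Cn2c(CCc3ccccc3)nnc2[C@H](NC(=O)Cc2ccccn2)c2c[nH]c3ccccc23)cc1` gives 3 nM in an in vitro assay on LLC-PK1 cells for displacement of a labelled ligand from growth hormone secretagogue receptor type 1 (Homo sapiens); on this read-out higher numbers stand for weaker inhibition and lower numbers for stronger inhibition. Compound 1 `CCc1ccc(Cn2c(CCc3ccccc3)nnc2[C@H](NC(=O)Cc2ccccn2)c2c[nH]c3ccccc23)cc1` gives 51 nM in this assay. Compound 3 `COc1ccc(Cn2c(CCc3ccccc3)nnc2[C@H](NC(=O)c2cnccn2)c2c[nH]c3ccccc23)cc1` gives 14 nM in this assay. The two measured steps each leave compound 2: one changes the benzyl substituent, (ethyl in place of methoxy on an aromatic carbon), and gives a 17-fold higher number from compound 2 to compound 1 (1.23 log units; beyond the scatter); the other changes the acyl group on the amide, (pyrazin-2-yl in place of (pyridin-2-yl)methyl on a carbonyl carbon), and gives a 4.7-fold higher number from compound 2 to compound 3 (0.67 log units; beyond the scatter).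

Compound 4 `CCc1ccc(Cn2c(CCc3ccccc3)nnc2[C@H](NC(=O)c2cnccn2)c2c[nH]c3ccccc23)cc1` is not yet measured in this assay. It differs from compound 3 by ethyl in place of methoxy on an aromatic carbon. The core of compound 3 and compound 4 differs from that of compound 2 and compound 1 by the acyl change told with pyrazin-2-yl in place of (pyridin-2-yl)methyl on a carbonyl carbon. The change from compound 3 to compound 4 is the same change as from compound 2 to compound 1, at the same place. The expected step is therefore taken as a 14-fold higher number from compound 3 to compound 4 (1.15 log units; beyond the scatter), resting on compound 2 and compound 1 giving a 17-fold higher number from compound 2 to compound 1 (1.23 log units; beyond the scatter) in this assay, and held somewhat short of it. Within the data shown here, only one measured instance of this change exists, and it sits on the core of compound 2 rather than on that of compound 3. Compound 4 is thus estimated at 200 nM in this assay, expected between 60 nM and 700 nM.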

Compound 4, half-maximal inhibitory concentration: 89 nM
The estimate for compound 4 lay 2.2-fold (0.35 log units) above the measured number; the range from low to high includes it.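

In this assay, ethyl in place of methoxy again gives a higher number on the core of compound 3, a 6.4-fold higher number from compound 3 to compound 4 (0.80 log units; beyond the scatter), so the direction of this change carries over to the second core, but its size does not: the same change on two cores in this assay, a 17-fold higher number (1.23 log units; beyond the scatter) from compound 2 to compound 1 and a 6.4-fold higher number (0.80 log units; beyond the scatter) from compound 3 to compound 4, 2.7-fold (0.43 log units) apart, beyond the scatter of two such steps

Read the other way round, the acyl change gives a 1.7-fold higher number from compound 1 to compound 4 (0.24 log units; within the scatter), which lies within the scatter, whereas it lay beyond the scatter on the methoxy compounds, so the two changes do not combine as independent steps across these four compounds: the same change on two cores in this assay, a 4.7-fold higher number (0.67 log units; beyond the scatter) from compound 2 to compound 3 and a 1.7-fold higher number (0.24 log units; within the scatter) from compound 1 to compound 4, 2.7-fold (0.43 log units) apart, beyond the scatter of two such steps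

This shows only a dependence between the two changes within one set of four compounds; it gives no cause for that dependence and no measure of how far it extends to other cores.

Going by these compounds, it remains open whether ethoxy or a longer chain in place of methoxy would show the same dependence on the acyl group. On these data alone, it is equally open whether an acyl group carrying an amine or a carboxylic acid would behave as the pyrazin-2-yl group does here.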